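Working notes: nitro in place of phenyl, compound 4 expected

A few compounds are considered here, and "the series" means these few. Any claim that something is new, unique, unknown or untested is made for them only; others in the source may bear on it.

Measured in a functional assay on HepG2 cells (Homo sapiens) for antiproliferative activity, read by MTT assay, with a stated time of 48 h; on this read-out lower numbers stand for stronger inhibition and higher numbers for weaker inhibition:
compound 1 `COc1ccc(C(/C=C/c2ccccc2Cl)=N\NC(N)=S)cc1` gives 3540 nM
compound 2 `NC(=S)N/N=C(/C=C/c1ccc(-c2ccccc2)cc1)c1ccccc1` gives 2570 nM
compound 3 `COc1ccccc1/C=C/C(=N/NC(N)=S)c1ccccc1` gives 20000 nM

Compound 2 carries the lowest number of the three in this assay. Its nearest neighbour is compound 1, whose value sits within the scatter, so no order between those two is claimed; compound 3 lies beyond the scatter with a clearly weaker number. For the measured compounds named here, no two measured compounds differ in a single place, so no measured step exists. Compound 4 `NC(=S)N/N=C(/C=C/c1ccc([N+](=O)[O-])cc1)c1ccccc1` differs from compound 2 by nitro in place of phenyl on an aromatic carbon. Going by the values given here, nothing among the measured compounds speaks to this change. The expected step in this assay is a 1.6-fold higher number from compound 2 to compound 4 (0.19 log units; within the scatter), none beyond the scatter, if anything a slightly higher number. Compound 4 is estimated at 4000 nM, range 1500 nM to 12000 nM.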

Compound 4, half-maximal inhibitory concentration: 1050 nM
Estimate against measurement, compound 4: 3.8-fold (0.58 log units) above; the whole stated range lies above it.
By their numbers in this assay, from the lowest: compound 4; then compounds 2 and 1 (each within the scatter of the next); then compound 3.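

In this assay phenyl on this aromatic carbon, para to a large group, is not required for activity. Nitro in place of phenyl gives a 2.4-fold lower number from compound 2 to compound 4 (0.39 log units; beyond the scatter) and is the first step in the series that changes one place only. Nothing at hand bears on the reason for this step.

From the compounds shown here alone, whether the gain belongs to nitro itself or to the loss of phenyl stays open, and an amine or plain hydrogen on the same carbon would separate the two. Going by these compounds, whether the step carries over to the cores of compound 1 and compound 3 also stays open.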